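A few compounds are considered here, and "the series" means these few. Any claim that something is new, unique, unknown or untested is made for them only; others in the source may bear on it.

Compound 3 `Brc1cc(NCc2cccs2)c2cn[nH]c2c1` gives 54% in an assay for inhibition of Indoleamine 2,3-dioxygenase 1 (Homo sapiens), with a stated time of 1 h, tested at 10 uM; a higher number here means more inhibition at the concentration tested (going by the name of the read-out), a lower number less inhibition. Among the three measured compounds it stands second highest: compound 1 `ONc1cccc(CNc2cc(Br)cc3[nH]ncc23)c1` gives 53%, a number within the usual scatter of compound 3, while compound 2 `N#Cc1ccc(CNc2cc(Br)cc3[nH]ncc23)cc1` gives 70%, a number that lies beyond the scatter above compound 3. Compound 4 `Nc1nc(CNc2cc(Br)cc3[nH]ncc23)cs1` has not yet been measured. It differs from compound 3 in one place (2-amino-1,3-thiazol-4-yl in place of thiophen-2-yl on a saturated chain carbon bound to a nitrogen on an aromatic ring). Going by the values given here, no step between two measured compounds is available to guide this change, so only a cautious expectation can be given in this assay. The step from compound 3 to compound 4 is expected to be small, a number 1 percentage points higher from compound 3 to compound 4 (within the scatter), with no direction beyond the scatter. Compound 4 is therefore estimated at 55%, with a range from 35% to 75%.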

Compound 4, a percentage reported as inhibition, at one concentration (the size of the read-out at that concentration, not a potency): "not active" (no number reported)
Compound 4 has no reported number here, and the estimate cannot be compared.
By their numbers in this assay, from the lowest: compounds 1 and 3 (each within the scatter of the next); then compound 2.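

In this assay, going by these compounds alone, compound 4 is reported as not active without a number, so no step from compound 3 to compound 4 can be read. The compounds shown leave open what 2-amino-1,3-thiazol-4-yl in place of thiophen-2-yl does to inhibition, and no measurement shown offers an explanation.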